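Branched Alkoxy Chains in a Bile Acid Receptor Series

The compounds below may be only part of what the source reports. "The series", "measured", "known", "first", "only" and "open" are said of these compounds alone.

Measured compounds:
compound 1 `CCOc1cccc(C(=O)Nc2cccc(C(=O)O)c2)c1` — 2350 nM
compound 2 `CCCCOc1cccc(C(=O)Nc2cccc(C(=O)O)c2)c1` — 3150 nM
compound 3 `CC(C)COc1cccc(C(=O)Nc2cccc(C(=O)O)c2)c1` — 1130 nM

In an assay on isolated protein for agonist activity at Bile acid receptor (Homo sapiens), read by TR-FRET, with a stated time of 3 h, in the absence of a further agent (on this read-out higher numbers stand for an effect only at larger amounts of compound and lower numbers for an effect already at smaller amounts), compound 3 gives the lowest number of the three; the steps of a 2.1-fold lower number from compound 1 to compound 3 (0.32 log units; beyond the scatter) and a 2.8-fold lower number from compound 2 to compound 3 (0.45 log units; beyond the scatter) are both beyond the scatter. Compound 4 `CC(C)CCOc1cccc(C(=O)Nc2cccc(C(=O)O)c2)c1` differs from compound 3 by isobutyl in place of isopropyl on a saturated chain carbon bound to an oxygen on an aromatic ring. Within the data shown here, two measured steps bear on this change. Extending the chain, in a 1.3-fold higher number from compound 1 to compound 2 (0.13 log units; within the scatter), stayed within the scatter, while introducing a branch, in a 2.8-fold lower number from compound 2 to compound 3 (0.45 log units; beyond the scatter), lowered the number. The move to compound 4 both adds a carbon to the chain and shifts the branch one bond outward, so these two observations pull in different directions, and neither is large. For compound 4 a step of a 1.3-fold higher number from compound 3 to compound 4 (0.12 log units; within the scatter) is therefore expected in this assay, meaning no clear change beyond the scatter or at most a slight rise. The value expected for compound 4 in this assay is 1500 nM, with a range from 700 nM to 3500 nM.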

Compound 4, half-maximal effective concentration: 2760 nM
Compound 4: middle estimate off by 1.8-fold (0.26 log units), on the low side, within the range that was stated.
By their numbers in this assay, from the lowest: compound 3; then compounds 1, 4 and 2 (each within the scatter of the next).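

In this assay, the lower number of compound 3 does not carry over to the isopentyloxy chain, since isobutoxy to isopentyloxy gives a 2.4-fold higher number from compound 3 to compound 4 (0.39 log units; beyond the scatter), so the exact form of the chain matters at this place and a branch alone does not settle the result. The other two steps confirm this: a 1.1-fold lower number from compound 2 to compound 4 (0.06 log units; within the scatter) and a 1.2-fold higher number from compound 1 to compound 4 (0.07 log units; within the scatter) both stay within the scatter, which leaves compound 3 as the only one of the four set apart from the others. Nothing available here accounts for this difference between the two branched chains.

As far as these compounds go, it remains open whether the lower number is special to the isobutoxy chain or is shared by close relatives such as a cyclopropylmethoxy or neopentyloxy group. From the compounds shown here alone, how a longer chain, or one ending in an amine, would read at this place also remains open.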